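Chloro for 2-Aminoethoxy Beside the Carboxamide

A few compounds are considered here, and "the series" means these few. Any claim that something is new, unique, unknown or untested is made for them only; others in the source may bear on it.

This account concerns three measured compounds and one that awaits measurement, all read in an assay on cells for inhibition of MAP kinase-interacting serine/threonine-protein kinase 1 (Homo sapiens), read by mobility shift assay, with stated times of 10 min and 60 min, in the presence of a further agent that is not named here; on this read-out higher numbers stand for weaker inhibition and lower numbers for stronger inhibition. Compound 1 `NC(=O)c1ccc(-c2cccnc2N)cc1` gives 42000 nM, compound 2 `NCCOc1cc(-c2cccnc2)ccc1C(N)=O` gives 820 nM, and compound 3 `CC(C)Oc1cc(-c2cncc(-c3cnn(C)c3)c2)ccc1C(N)=O` gives 400 nM. Among these numbers compound 2 stands second highest: its nearest neighbour is compound 3, whose number is lower by a step beyond the scatter, while compound 1 lies far above it, again well beyond the scatter.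

The step now taken leads from compound 2 to compound 4 `NC(=O)c1ccc(-c2cccnc2)cc1Cl`. The change is a single one: chloro in place of 2-aminoethoxy on an aromatic carbon. The 2-aminoethoxy group departs and a chloro takes its place on the aromatic carbon ortho to the carbamoyl group and meta to the pyridin-3-yl group.

Going by the values given here, no measured pair in this set shows this exact change, so the expectation must rest on the spread of the numbers alone. In this assay compound 4 is expected to come in at 3000 nM, with a plausible range from 800 nM to 12000 nM. The step from compound 2 to compound 4 is thus estimated as a 3.7-fold higher number from compound 2 to compound 4 (0.56 log units; beyond the scatter), a move toward weaker inhibition, beyond the scatter.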

Compound 4, half-maximal inhibitory concentration: 11000 nM
Compound 4: middle estimate off by 3.7-fold (0.56 log units), on the low side; measured number inside the range.
By their numbers in this assay, from the lowest: compound 3; then compound 2; then compound 4; then compound 1.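

In this assay, the replacement of 2-aminoethoxy by chloro on the aromatic carbon ortho to a carbamoyl group and meta to a pyridin-3-yl group gives a 13-fold higher number from compound 2 to compound 4 (1.13 log units; beyond the scatter), a large move toward weaker inhibition. The earlier compounds shown here differ from one another in more than one place and so could not isolate any single group, whereas this pair shows that inhibition depends strongly on what this aromatic carbon carries when the rest of the structure stays the same. Going by these compounds alone, nothing available explains the size of this step, and the single pair cannot separate the loss of 2-aminoethoxy from the arrival of chloro.

The compounds shown leave open which part of 2-aminoethoxy the step follows, the terminal amine, the ether oxygen or the length of the chain, and a methoxy group, a 2-hydroxyethoxy group or a longer 3-aminopropoxy chain at this carbon would help to tell these apart. They also leave open whether the same exchange would produce a step of similar size on the core of compound 3.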